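The compounds below may be only part of what the source reports. "The series", "measured", "known", "first", "only" and "open" are said of these compounds alone.

Compounds measured in a functional assay on MCF7 cells (Homo sapiens) for inhibition, read by sulforhodamine B assay, with a stated time of 48 h; a lower number here means a stronger inhibitor of growth, a higher number a weaker inhibitor of growth:
compound 1 `O=C(Nc1cccc(-n2cc(-c3ccncc3)c(-c3ccc(Cl)c(O)c3)n2)c1)Nc1cccc(C(F)(F)F)c1` gives 1340 nM
compound 2 `COc1cc(-c2nn(-c3cccc(NC(=O)c4cccc(C(F)(F)F)c4)c3)cc2-c2ccncc2)ccc1Cl` gives 1430 nM
compound 3 `O=C(Nc1cccc(-n2cc(-c3ccncc3)c(-c3ccc(Cl)c(O)c3)n2)c1)Nc1cc(C(F)(F)F)cc(C(F)(F)F)c1` gives 540 nM

Compound 2 holds the highest of the three numbers in this assay. Compound 1 is nearest to it and the two lie within the scatter of each other; compound 3 is furthest, beyond the scatter. Going by the values given here, the only single-point step known here, a 2.5-fold lower number from compound 1 to compound 3 (0.39 log units; beyond the scatter), shows that adding a trifluoromethyl to the aryl of the urea moves the number down modestly.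

Compound 4 `COc1cc(-c2nn(-c3cccc(NC(=O)Nc4ccc(Cl)c(C(F)(F)F)c4)c3)cc2-c2ccncc2)ccc1Cl` is compound 2 with (4-chloro-3-(trifluoromethyl)phenyl)amino in place of 3-(trifluoromethyl)phenyl on a carbonyl carbon. This is a larger change than any measured step: the amide of compound 2 becomes a urea bearing an aryl carrying both chlorine and trifluoromethyl. Among the compounds with values here, no measured pair isolates the amide-to-urea change; compounds 1 and 2 differ in two places, and their values in this assay are within the scatter of each other. Within the data shown here, the step of a 2.5-fold lower number from compound 1 to compound 3 (0.39 log units; beyond the scatter) is the only guide to the effect of extra substitution on the urea aryl. A modest downward step is therefore expected, a 1.8-fold lower number from compound 2 to compound 4 (0.25 log units; within the scatter), with wide uncertainty. Compound 4 is estimated at 800 nM, with a range of 350 nM to 2000 nM.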

Compound 4, concentration for 50% growth inhibition: 919 nM
For compound 4 the middle estimate is 1.1-fold (0.06 log units) below the measured one; measured number inside the range.
By their numbers in this assay, from the lowest: compounds 3, 4, 1 and 2 (each within the scatter of the next, the first and the last beyond it).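

In this assay, (4-chloro-3-(trifluoromethyl)phenyl)amino in place of 3-(trifluoromethyl)phenyl on a carbonyl carbon gives a 1.6-fold lower number from compound 2 to compound 4 (0.19 log units; within the scatter), so this first measured change at the carbonyl carbon of compound 2 stays within the scatter. The exchange adds a nitrogen, a chlorine and a hydrogen-bond donor without a resolved shift in the number, which shows that this position accepts the larger urea-linked aryl with no measurable loss or gain in this assay. No measurement shown here bears on why the number holds.

The contributions of the amide-to-urea exchange and the chlorine remain unseparated, as the two enter together. Also open, going by these compounds, is whether a nitrile, an amine or a carboxylic acid in place of the chlorine on this aryl would move the number beyond the scatter.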